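Dichlorobenzyl ethers: moving the second chlorine

The source may report more compounds than this note shows. Statements on the series, on what has been measured and on what is new or still open speak of the compounds shown alone.

Compound 1 `Cc1ccc(NC(=S)NC(=O)c2ccc(OCc3ccccc3)cc2)cc1-c1nc2ccccc2[nH]1` carries an unsubstituted benzyl ether; in a functional assay on MNK45 cells (Homo sapiens) for inhibition, read by MTT assay, with a stated time of 48 h (on this read-out higher numbers stand for weaker inhibition and lower numbers for stronger inhibition), compound 1 gives 57800 nM. Compound 3 `Cc1ccc(NC(=S)NC(=O)c2ccc(OCc3ccc(Cl)c(Cl)c3)cc2)cc1-c1nc2ccccc2[nH]1` gives 8410 nM. Compound 2 `Cc1ccc(NC(=S)NC(=O)c2ccc(OCc3cccc(Cl)c3Cl)cc2)cc1-c1nc2ccccc2[nH]1` gives only a limit of the assay, > 100000 nM, and so stands at the weak end of the three compounds shown, without a number of its own. Compound 4 `Cc1ccc(NC(=S)NC(=O)c2ccc(OCc3ccc(Cl)cc3Cl)cc2)cc1-c1nc2ccccc2[nH]1` differs from compound 2 by 2,4-dichlorophenyl in place of 2,3-dichlorophenyl on a saturated chain carbon bound to an oxygen on an aromatic ring. The measured steps that bear on it are an at least 1.7-fold higher number from compound 1 to compound 2 (0.23 log units; that floor lies within the scatter), a 6.9-fold lower number from compound 1 to compound 3 (0.84 log units; beyond the scatter) and an at least 11-fold lower number from compound 2 to compound 3 (1.07 log units; beyond the scatter). Since 2,4-dichlorophenyl shares one chlorine placement with 2,3-dichlorophenyl and one with 3,4-dichlorophenyl, a step down from the limit, smaller than an at least 11-fold lower number from compound 2 to compound 3 (1.07 log units; beyond the scatter), is expected: an at least 2.8-fold lower number from compound 2 to compound 4 (0.45 log units; beyond the scatter). Compound 4 is therefore expected to give 35000 nM in this assay, with a range from 8000 nM to 100000 nM.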

Compound 4, half-maximal inhibitory concentration: 5300 nM
Compound 4: the middle estimate sits 6.6-fold (0.82 log units) above what was measured; the whole stated range lies above it.
By their numbers in this assay, from the lowest: compounds 4 and 3 (each within the scatter of the next); then compound 1. At a limit, above all of these: compound 2.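

Sharing one chlorine placement with 2,3-dichlorophenyl does not carry over the weak result of compound 2: an at least 18-fold lower number from compound 2 to compound 4 (1.27 log units; beyond the scatter). That step is only a floor, because compound 2 stands at a limit of the assay: the limit of > 100000 nM in this assay, at which 1 of the 4 values shown sits. The 2,4-dichlorophenyl and 3,4-dichlorophenyl ethers cannot be told apart, with a 1.6-fold lower number from compound 3 to compound 4 (0.20 log units; within the scatter), while the gain over the unsubstituted benzyl ether is clear, with an 11-fold lower number from compound 1 to compound 4 (1.04 log units; beyond the scatter).

Still open, going by these compounds, is whether a single chlorine would hold this level. Also open, on these data alone, is whether a methoxy group or an amine in place of either chlorine would do so.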